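Working notes: amine swap from compound 3 to compound 4

The source may report more compounds than this note shows. Statements on the series, on what has been measured and on what is new or still open speak of the compounds shown alone.

In a functional assay on A549 cells (Homo sapiens) for antiproliferative activity, read by MTT assay, with a stated time of 48 h (on this read-out lower numbers stand for stronger inhibition and higher numbers for weaker inhibition), compound 1 (`CC(C)=CCC[C@]1(C)/C=C/[C@@H](OC(=O)C=C(C)C)[C@](C)(O)/C=C/C(=O)/C(C(=O)O)=C\C1`) gives > 10000 nM as a limit of the assay and not a number. Compound 2 (`CCN(CC)C/C1=C/C[C@](C)(CCC=C(C)C)/C=C/[C@@H](OC(=O)C=C(C)C)[C@](C)(O)/C=C/C1=O`) reaches 130 nM and compound 3 (`CC(C)=CCC[C@]1(C)/C=C/[C@@H](OC(=O)C=C(C)C)[C@](C)(O)/C=C/C(=O)/C(CN(C(C)C)C(C)C)=C\C1`) sits at 650 nM as the higher of these two numbers. Compound 4 (`CC(C)=CCC[C@]1(C)/C=C/[C@@H](OC(=O)C=C(C)C)[C@](C)(O)/C=C/C(=O)/C(CN2CCN(C)CC2)=C\C1`) differs from compound 3 by one change (4-methylpiperazin-1-yl in place of diisopropylamino on a saturated chain carbon bound to a double-bonded ring carbon) with 4-methylpiperazin-1-yl in place of diisopropylamino on a saturated chain carbon bound to a double-bonded ring carbon. The closest measured step is the modest 5.0-fold higher number from compound 2 to compound 3 (0.70 log units; beyond the scatter) between two amino groups. The large steps of an at least 76-fold lower number from compound 1 to compound 2 (1.88 log units; beyond the scatter) and an at least 15-fold lower number from compound 1 to compound 3 (1.18 log units; beyond the scatter) start from carboxy and bear less directly. A step of modest size at most is therefore expected in this assay with a slight lean to lower numbers. An expected step of a 1.3-fold lower number from compound 3 to compound 4 (0.11 log units; within the scatter) is the working figure here. Compound 4 is expected at 500 nM within an estimated range from 150 nM to 2500 nM in this assay for now.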

Compound 4, half-maximal inhibitory concentration: 940 nM
Estimate against measurement, compound 4: 1.9-fold (0.27 log units) below; the measured number falls inside the stated range.
By their numbers in this assay, from the lowest: compound 2; then compounds 3 and 4 (each within the scatter of the next). At a limit, above all of these: compound 1.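

In this assay, a ring amine is accepted on this saturated chain carbon: 4-methylpiperazin-1-yl in place of diisopropylamino gives a 1.4-fold higher number from compound 3 to compound 4 (0.16 log units; within the scatter). Against diethylamino, the same group gives a 7.2-fold higher number from compound 2 to compound 4 (0.86 log units; beyond the scatter), so among the three amines only diethylamino stands apart. The step of an at least 10-fold lower number from compound 1 to compound 4 (1.02 log units; beyond the scatter) extends the gain over carboxy to a ring amine, though it starts from a limit of the assay and not a number: the limit of > 10000 nM in this assay, at which 1 of the 4 values shown sits.

Going by these compounds, whether dimethylamino, pyrrolidin-1-yl or morpholin-4-yl would match diethylamino stays open. The compounds shown also do not tell why diethylamino differs.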